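The compounds below may be only part of what the source reports. "The series", "measured", "known", "first", "only" and "open" are said of these compounds alone.

Working notes on the series. Compound 1 `CC(C)[C@H](NC(=O)CN(c1nc(Cl)nc2[nH]cnc12)C1CC1)C(=O)OCc1ccccc1` was tested in a functional assay on the whole organism (Tail, strain ICR) with Mus musculus as the target, in the tail flick test, with a stated time of 30 min, at a dose of 25 umol/kg by the oral route (on this read-out higher numbers stand for a stronger effect at the one dose given and lower numbers for a weaker effect), where compound 1 gives 33.4%. Compound 2 `CC(C)[C@H](NC(=O)CN(c1nc(Cl)nc2[nH]cnc12)C1CC1)C(=O)O` differs from it by hydrogen in place of benzyl on an oxygen next to a carbonyl group, and in this assay compound 2 gives 31.2%; the step of a number 2.2 percentage points lower from compound 1 to compound 2 (within the scatter) lies within the scatter. Among the compounds with values here, on the two numbers so far compound 1 holds the higher one, though its gap to compound 2 is within the scatter, so no order is claimed.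

Compound 3 `CSCC[C@H](NC(=O)CN(c1nc(Cl)nc2[nH]cnc12)C1CC1)C(=O)OCc1ccccc1` has not yet been measured in this assay. Its change from compound 1 is 2-(methylsulfanyl)ethyl in place of isopropyl on a saturated chain carbon bound to an amide-type nitrogen and a carbonyl carbon. Within the data shown here, no measured step touches this position or this exchange, so the one step known, a number 2.2 percentage points lower from compound 1 to compound 2 (within the scatter), bears on it only as a sign that the series has so far moved little. A step of about a number 1.4 percentage points lower from compound 1 to compound 3 (within the scatter) is therefore expected, with no direction beyond the scatter. Compound 3 is estimated to give 32% in this assay, within a range from 18% to 46%.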

Compound 3, a percentage reported as activity, at one dose (the size of the read-out at that dose, not a potency): 22.2%
Estimate against measurement, compound 3: 9.8 percentage points above; measured number inside the range.
By their numbers in this assay, from the lowest: compounds 3, 2 and 1 (each within the scatter of the next, the first and the last beyond it).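

In this assay, within the data shown here, the position on a saturated chain carbon bound to an amide-type nitrogen and a carbonyl carbon is the first place where one exchange moves the read-out beyond the scatter: 2-(methylsulfanyl)ethyl in place of isopropyl gives a number 11.2 percentage points lower from compound 1 to compound 3 (beyond the scatter), whereas the change at the ester gave only a number 2.2 percentage points lower from compound 1 to compound 2 (within the scatter). The position is therefore not indifferent to the group it carries, although the step is modest and rests on one pair with the benzyl ester held constant. Nothing available on these compounds accounts for the step.

An n-butyl chain at this position would help separate the role of the sulfur from that of the unbranched chain, while methyl would test a much shorter group. A carboxylic acid in place of the benzyl ester of compound 3 would show whether the ester change stays as small with this side chain.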